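Swapping the Pyridyl Arm of Compound 1 for a Thioester Chain

A few compounds are considered here, and "the series" means these few. Any claim that something is new, unique, unknown or untested is made for them only; others in the source may bear on it.

Compound 1 `O=C(CCCCCCc1ccccc1)c1ncc(-c2ccc(CO)cn2)o1`: 3.2 nM
Compound 2 `CCOS(=O)(=O)/C=C/c1ccc(-c2cnc(C(=O)CCCCCCc3ccccc3)o2)nc1`: 2.1 nM
Compound 3 `C[S+]([O-])/C=C/c1ccc(-c2cnc(C(=O)CCCCCCc3ccccc3)o2)nc1`: 3 nM

In an assay for inhibition of Fatty-acid amide hydrolase 1 (Rattus norvegicus), using a Dixon plot (on this read-out higher numbers stand for weaker inhibition and lower numbers for stronger inhibition), compound 1 gives the highest of the three numbers, but a 1.5-fold lower number from compound 1 to compound 2 (0.18 log units; within the scatter) and a 1.1-fold lower number from compound 1 to compound 3 (0.03 log units; within the scatter) both lie within the scatter, so the three compounds cannot be ordered. Compound 4 `CSC(=O)CCCCc1cnc(C(=O)CCCCCCc2ccccc2)o1` differs from compound 1 as follows: a group of 8 heavy atoms (6 carbon, 1 oxygen, 1 sulfur; no ring) in place of a group of 8 heavy atoms (6 carbon, 1 nitrogen, 1 oxygen; one six-membered aromatic ring with 1 hetero atom), on an aromatic carbon. The measured steps only exchange the substituent on the six-membered ring while keeping that ring, so they bear on this change only loosely; they show that small edits at this end of the shared core left this assay unchanged. On these data alone, replacing the whole ring by a chain is untested here, so the expected step of a 1.9-fold higher number from compound 1 to compound 4 (0.27 log units; within the scatter) is small but uncertain. Compound 4 is therefore estimated at 6 nM, within a range from 1.5 nM to 30 nM.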

Compound 4, inhibition constant: 1.8 nM
For compound 4 the middle estimate is 3.3-fold (0.52 log units) above the measured one, within the range that was stated.
By their numbers in this assay, from the lowest: compounds 4, 2, 3 and 1 (each within the scatter of the next).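

In this assay, exchanging the 5-(hydroxymethyl)pyridin-2-yl group for an open chain ending in a thioester gives a 1.8-fold lower number from compound 1 to compound 4 (0.25 log units; within the scatter). Earlier steps all kept the six-membered aromatic ring, whereas this one shows that the ring and its hydrogen-bond donor can both leave this position without a change beyond the scatter. Nothing available explains this result. The compounds shown leave open whether the thioester end of the chain matters, and whether a carboxylic acid, an amine or a longer chain at this position would give a similar number.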